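This account rests on a few compounds, and the source may have more. Where it says the series, first, only, none or still open, it means among the compounds named here.

Compound 1 `Cc1ccc(N2CCN(Cn3nc(-c4ccc5c(c4)OCCO5)oc3=S)CC2)c(C)c1` and compound 2 `Fc1ccc(N2CCN(Cn3nc(-c4ccc5c(c4)OCCO5)oc3=S)CC2)cc1` share one core and differ only in the aryl group on the amine nitrogen in a ring. In a functional assay on HepG2 cells (Homo sapiens) for antiproliferative activity, read by MTT assay, with a stated time of 48 h (on this read-out lower numbers stand for stronger inhibition and higher numbers for weaker inhibition), compound 1 gives 28400 nM. In this assay compound 2 gives > 50000 nM, which is a limit of the assay and not a number. Compound 2 stands at the limit of > 50000 nM in this assay, at which 1 of the 2 values shown sits. The step of an at least 1.7-fold higher number from compound 1 to compound 2 (0.24 log units; that floor lies within the scatter) can therefore be sized only at its floor. Compound 3 `S=c1oc(-c2ccc3c(c2)OCCO3)nn1CN1CCN(c2ccccn2)CC1` carries the change (pyridin-2-yl in place of 4-fluorophenyl on an amine nitrogen in a ring). Among the measured compounds shown here, the only measured step that bears on this position of the shared core is an at least 1.7-fold higher number from compound 1 to compound 2 (0.24 log units; that floor lies within the scatter), and it gives no size for a further exchange of the aryl group beyond what the limit allows. Compound 3 is expected to remain close to where compound 2 sits, so the step of a number no higher from compound 2 to compound 3 (the limit leaves the size open) is estimated to lie within the scatter. For compound 3 the expected value in this assay is 50000 nM, with a range from 18000 nM to 150000 nM, and a limit rather than a number is quite likely to be reported.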

Compound 3, half-maximal inhibitory concentration: 11400 nM
Compound 3: the middle estimate sits 4.4-fold (0.64 log units) above what was measured; measured number below the stated range.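

In this assay, this position on the amine nitrogen in a ring now shows a response of readable size: pyridin-2-yl in place of 4-fluorophenyl gives an at least 4.3-fold lower number from compound 2 to compound 3 (0.64 log units; beyond the scatter), and pyridin-2-yl in place of 2,4-dimethylphenyl gives a 2.5-fold lower number from compound 1 to compound 3 (0.40 log units; beyond the scatter). Among the compounds shown here, the one earlier step here had a floor within the scatter, whereas both new steps lie beyond it, so the choice of aryl group at this position does change the read-out, and pyridin-2-yl is the group with the lowest number of the three. The step from the fluorinated compound can still be sized only at its floor, as compound 2 stands at a limit of the assay and not at a number: the limit of > 50000 nM in this assay, at which 1 of the 3 values shown sits.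

The compounds shown leave open how much of this change belongs to the ring nitrogen of pyridin-2-yl, a question that an unsubstituted phenyl on the same amine nitrogen would address. They also leave open whether pyridin-3-yl, pyridin-4-yl or pyrimidin-2-yl at this position would give a lower or a higher number.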